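Trading 1-methyl-1H-pyrazol-3-yl for benzoyl

The source may report more compounds than this note shows. Statements on the series, on what has been measured and on what is new or still open speak of the compounds shown alone.

Within the data shown here, in a physicochemical assay for solubility, read by LC-MS, in phosphate buffer, with a stated time of 24 h, at pH 7.4 (on this read-out lower numbers stand for lower solubility and higher numbers for higher solubility), compound 2 (`CN(c1ccn(C)n1)c1cnc(NCc2c(F)ccc3c2CCO3)n2cnnc12`) gives 130000 nM as the higher of the two numbers so far. Compound 1 (`O=C1c2ccccc2CN1c1cnc(NCc2c(F)ccc3c2CCO3)n2cnnc12`) gives 4000 nM on the same read-out. Compound 3 (`CN(C(=O)c1ccccc1)c1cnc(NCc2c(F)ccc3c2CCO3)n2cnnc12`) has no number yet. It differs from compound 2 in one place (benzoyl in place of 1-methyl-1H-pyrazol-3-yl on a nitrogen on an aromatic ring), with benzoyl in place of 1-methyl-1H-pyrazol-3-yl on a nitrogen on an aromatic ring.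

Among the measured compounds shown here, only one measured step bears on this change. The large move of a 33-fold higher number from compound 1 to compound 2 (1.51 log units; beyond the scatter) lies beyond the scatter and came with the arrival of a five-membered aromatic ring with 2 hetero atoms and the loss of a six-membered aromatic ring of carbon only. Compound 3 runs partly the other way, giving up the first kind of ring and regaining the second, so a fall is expected. One pair of compounds cannot fix its size, and benzoyl is not the group that compound 1 carries, so only part of that distance is expected. The expected move is a 5.2-fold lower number from compound 2 to compound 3 (0.72 log units; beyond the scatter) in this assay as an estimate. For compound 3 the estimate is 25000 nM with an expected range from 6000 nM to 100000 nM on this read-out.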

Compound 3, solubility: 280000 nM
Compound 3: middle estimate off by 11-fold (1.05 log units), on the low side; measured number above the stated range.
By their numbers in this assay, from the lowest: compound 1; then compound 2; then compound 3.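

In this assay, placing benzoyl on the nitrogen in place of 1-methyl-1H-pyrazol-3-yl does not bring the number down towards that of compound 1; the change gives a 2.2-fold higher number from compound 2 to compound 3 (0.33 log units; beyond the scatter). So a six-membered aromatic ring of carbon only at this place does not by itself go with a low number, and the step of a 70-fold higher number from compound 1 to compound 3 (1.85 log units; beyond the scatter) makes the same point, since that ring is present in both compounds and the step comes with the loss of the five-membered non-aromatic ring with 1 hetero atom. Nothing measured here gives a reason for either step.

Three compounds on a single read-out cannot separate the part played by the carbonyl of benzoyl from that of its aromatic ring, and a benzyl group on the same nitrogen, with a plain carbon in place of the carbonyl, would pull the two apart. Going by these compounds, it also remains open whether the high number would hold with a further group on the benzoyl ring, such as an amine or a carboxylic acid.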